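The source may hold more compounds than are shown below. What is called first, only, known or untested is meant among the compounds shown, and "the series" means these compounds.

Three close relatives of a shared core were examined in an assay for inhibition of Polyunsaturated fatty acid lipoxygenase ALOX15 (Oryctolagus cuniculus); a lower number here means a stronger inhibitor, a higher number a weaker inhibitor. Compound 1, `COc1ccc(C(=O)Oc2c(-c3ccccc3)c(-c3ccccc3)n3ccc(C#N)cc23)cc1`, returned "not determined" (no result reported), so it contributes no number. For the measured compounds named here, compound 2, `Cc1ccc(S(=O)(=O)Oc2c(-c3ccccc3)c(-c3ccccc3)n3ccc(C#N)cc23)cc1`, was the only one of the group with a reported result; in this assay compound 2 gives 25000 nM, a weak inhibition. Compound 3, `N#Cc1ccn2c(-c3ccccc3)c(-c3ccccc3)c(OCc3ccc(F)cc3)c2c1`, also came back with "not determined" (no result reported) in this assay, so there is no figure on which compound 3 can be placed: among the three, only compound 2 carries a number, and compound 3 stands beside compound 1 as one of two entries without one.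

Compound 4, `N#Cc1ccn2c(-c3ccccc3)c(-c3ccccc3)c(C(=O)c3ccccc3)c2c1`, has not been tested. It differs from compound 3 in one place: benzoyl in place of (4-fluorobenzyl)oxy on an aromatic carbon. Going by the values given here, nothing among the measured compounds connects these two, so no step size from compound 3 can be stated. The only anchor is the weak result of compound 2, which shares the core with both. With that anchor alone, a value for compound 4 in the same weak region is the most reasonable expectation, with no direction of change from compound 3 claimed and a wide spread to allow for the absence of any guiding step. For compound 4 in this assay the estimated value is 20000 nM, expected to lie between 3000 nM and 100000 nM.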

Compound 4, half-maximal inhibitory concentration: 43000 nM
Beside the measured number, compound 4's estimate is 2.2-fold (0.33 log units) below it, within the range that was stated.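

In this assay, placing benzoyl on this aromatic carbon in place of ((4-methylphenyl)sulfonyl)oxy gives a 1.7-fold higher number from compound 2 to compound 4 (0.24 log units; within the scatter), so the two compounds cannot be told apart. This position therefore accepts two quite different groups, one joined through a carbonyl and the other through a sulfonyl and an oxygen, with no measurable difference in the result, and both compounds remain weak inhibitors. No supporting measurement is available to explain why this exchange leaves the number so little changed.

Steps involving compound 1 or compound 3 cannot be read, as neither has a reported number, so the effect of removing (4-fluorobenzyl)oxy in favour of benzoyl remains unknown. From the compounds shown here alone, it also remains open whether a much smaller or chemically different group on this carbon, such as a hydroxyl, an amine or a carboxylic acid, would give a clearly lower number than the two groups compared here.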